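The source may hold more compounds than are shown below. What is called first, only, known or untested is meant among the compounds shown, and "the series" means these compounds.

Measured compounds in an ADME assay on microsomes from liver (Homo sapiens) for metabolic stability; on this read-out higher numbers stand for a longer-lived compound and lower numbers for a shorter-lived compound:
compound 1 `COc1cc(OCc2csc(-c3ccc(C(C)(C)O)cc3)n2)c2cc(-c3cn4nc(OC)sc4n3)oc2c1`, 1.83 h
compound 2 `COc1cc(OCc2cccc(-c3ccc(C#N)cn3)c2)c2cc(-c3cn4nc(OC)sc4n3)oc2c1`, 1.57 h
compound 3 `COc1cc(OCc2csc(-c3ccc(S(C)(=O)=O)cc3)n2)c2cc(-c3cn4nc(OC)sc4n3)oc2c1`, 1.22 h

The three numbers lie within the scatter of one another; the number of compound 2 sits between those of compound 1 and compound 3, both of which are within the scatter of it. Going by the values given here, the single step between compounds differing in one place, a 1.5-fold lower number from compound 1 to compound 3 (0.18 log units; within the scatter), also stays within the scatter.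

Compound 4 `COc1ccc(-c2cccc(COc3cc(OC)cc4oc(-c5cn6nc(OC)sc6n5)cc34)c2)nc1` has not yet been measured in this assay. Compared with compound 2 it differs as follows: methoxy in place of cyano on an aromatic carbon

Among the compounds with values here, no measured step covers this exchange of a cyano for a methoxy group. Within the data shown here, the one step available, a 1.5-fold lower number from compound 1 to compound 3 (0.18 log units; within the scatter), concerns other groups on another ring, and it was within the scatter. Among the measured compounds shown here, the series so far shows no change beyond the scatter from any substituent exchange, so no step beyond the scatter is expected here either, in no particular direction. For compound 4 the half-life in this assay is estimated at 1.6 h, with a range of 0.9 h to 2.8 h, which means an expected step of a 1.0-fold higher number from compound 2 to compound 4 (0.01 log units; within the scatter).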

Compound 4, half-life: 0.767 h
For compound 4 the middle estimate is 2.1-fold (0.32 log units) above the measured one, and the stated range ends above it.
By their numbers in this assay, from the lowest: compounds 4, 3, 2 and 1 (each within the scatter of the next, the first and the last beyond it).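

In this assay, going by these compounds alone, going from 5-cyanopyridin-2-yl to 5-methoxypyridin-2-yl gives a 2.0-fold lower number from compound 2 to compound 4 (0.31 log units; beyond the scatter), a modest change and the first step to leave the scatter. This aromatic carbon, two atoms from the ring nitrogen and para to a large group, is therefore a place where a substituent exchange registers in the half-life, which the step between compound 1 and compound 3 on the other ring did not show. Cyano and methoxy match in heavy atoms, hydrogen-bond donors and hydrogen-bond acceptors as counted, so those counts do not separate them, and no available measurement bears on the reason for the step.

As far as these compounds go, whether the shift is specific to methoxy or follows any loss of cyano remains open. A fluorine, an amine or an ethoxy group at this carbon would help to separate these cases, and the same exchange on the core of compound 1 would test whether the step carries over.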